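Title: Replacing the pyrazinyl group in a quinazoline alpha-1 ligand

The compounds below may be only part of what the source reports. "The series", "measured", "known", "first", "only" and "open" are said of these compounds alone.

Of the compounds shown here, two from a shared core have been measured in an assay on brain for binding affinity to Adrenergic receptor alpha-1 (Rattus norvegicus); a lower number here means a stronger inhibitor, a higher number a weaker inhibitor. Compound 1 `COc1cc2nc(N3CCN(c4cccnn4)CC3)nc(N)c2cc1OC` gives 0.4 nM. Compound 2 `COc1cc2nc(N3CCN(c4cnccn4)CC3)nc(N)c2cc1OC` gives 0.18 nM, the lowest of the two numbers; the step from the first to the second, a 2.2-fold lower number from compound 1 to compound 2 (0.35 log units; beyond the scatter), is modest but beyond the scatter and marks compound 2 as the stronger inhibitor of the pair.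

Compound 3 `COc1cc2nc(N3CCN(c4cc(OC(C)C)ncn4)CC3)nc(N)c2cc1OC` has not yet been tested in this assay. It differs from compound 2 in one place: 6-isopropoxypyrimidin-4-yl in place of pyrazin-2-yl on an amine nitrogen in a ring. Among the measured compounds shown here, the only measured step, a 2.2-fold lower number from compound 1 to compound 2 (0.35 log units; beyond the scatter), also exchanges one six-membered aromatic ring for another at this ring nitrogen, and it was modest in size. For the measured compounds named here, no measured step shows the effect of the isopropoxy group, so the direction is uncertain. Compound 3 is therefore expected to stay near compound 2, with a step of a 1.7-fold higher number from compound 2 to compound 3 (0.22 log units; within the scatter) and an estimated value of 0.3 nM, within the range 0.08 nM to 1.2 nM.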

Compound 3, inhibition constant: 0.18 nM
For compound 3 the middle estimate is 1.7-fold (0.22 log units) above the measured one; measured number inside the range.
By their numbers in this assay, from the lowest: compounds 2 and 3 (each within the scatter of the next); then compound 1.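

At this position, on an amine nitrogen in a ring, the exchange of pyrazin-2-yl for 6-isopropoxypyrimidin-4-yl gives no change at the digits printed from compound 2 to compound 3 (within the scatter) in this assay, so a group with an added isopropoxy substituent is compatible with a number as low as that of compound 2. Measured against pyridazin-3-yl, the same group gives a 2.2-fold lower number from compound 1 to compound 3 (0.35 log units; beyond the scatter), a step that matches a 2.2-fold lower number from compound 1 to compound 2 (0.35 log units; beyond the scatter), so among these three compounds only compound 1 stands apart from the others. The data shown offer no explanation for this result.

From the compounds shown here alone, how much the isopropoxy group itself contributes stays open, as does the value in this assay of a plain pyrimidin-4-yl group. Also open, going by these compounds, is whether a methoxy group, an amine or a carboxylic acid in place of the isopropoxy group would keep the number this low.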